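The source may report more compounds than this note shows. Statements on the series, on what has been measured and on what is new or still open speak of the compounds shown alone.

Three compounds of this series have a reading in a functional assay on MDA-MB-231 cells (Homo sapiens) for inhibition, read by CCK-8 assay, with a stated time of 48 h; a lower number here means a stronger inhibitor of growth, a higher number a weaker inhibitor of growth. Compound 1 `Cc1ccccc1Nc1nc(NC2CCCCC2)ncc1Cl` returns only a limit of the assay, > 100000 nM. Compound 2 `Cc1ccc(Nc2ncc(Cl)c(Nc3ccccc3C)n2)cc1` likewise returns a limit, > 100000 nM. The step that the two limits leave unreadable from compound 1 to compound 2 therefore cannot be read because the limit of > 100000 nM in this assay, at which 2 of the 3 values shown sit, holds both of its ends. Among the measured compounds shown here, compound 3 `CN1CCN(c2ccc(Nc3ncc(Cl)c(NCc4ccccc4)n3)nc2)CC1` is the one compound with a number: in this assay compound 3 gives 24800 nM. For the measured compounds named here, it stands as the only measured value among the three.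

Compound 4 `Cc1cccc(Nc2nc(Nc3ccc(N4CCN(C)CC4)cn3)ncc2Cl)c1` is the next compound to be measured in this assay. The change from compound 3 is 3-methylphenyl in place of benzyl on a nitrogen on an aromatic ring. Going by the values given here, no measured step bears on this change: the single step between measured compounds, from compound 1 to compound 2, is unreadable and concerns a different nitrogen on the shared core. With nothing to lean on, the expectation is a step of no size beyond the scatter, in no particular direction; the step expected in this assay is estimated as a 1.0-fold higher number from compound 3 to compound 4 (0.00 log units; within the scatter). For compound 4 the expected value in this assay is 25000 nM, with a range from 6000 nM to 100000 nM.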

Compound 4, concentration for 50% growth inhibition: 5270 nM
The estimate for compound 4 lay 4.7-fold (0.68 log units) above the measured number, and the stated range ends above it.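

Notes on the nitrogen-bound group: the only earlier step, between compounds 1 and 2, cannot be read, so this change gives the first readable effect of a substituent in this assay, with a 4.7-fold lower number from compound 3 to compound 4 (0.67 log units; beyond the scatter). Benzyl and 3-methylphenyl have the same heavy-atom count, the same carbon-only six-membered aromatic ring and the same donor and acceptor counts, and compounds 3 and 4 hold the same atoms, so this step beyond the scatter arises with no change in composition, only in how the atoms are joined, from benzylamino to (3-methylphenyl)amino. Among the compounds shown here, nothing measured here gives a cause for the step, and the single pair supports no general rule for this position.

The pair cannot separate the loss of the carbon link between the nitrogen and the ring from the presence of the methyl, and a plain phenyl on the same nitrogen would be the direct test of that. Also open, on these data alone, is how far the position tolerates other groups, such as a longer chain like 2-phenylethyl, or an amine or a carboxylic acid in place of the methyl on the 3-methylphenyl ring.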